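This account rests on a few compounds, and the source may have more. Where it says the series, first, only, none or still open, it means among the compounds named here.

Compound 1 `CCCCCCOc1cc(OC)c(Br)cc1C(C)=O` gives 42400000 nM
Compound 2 `CCCCCCCCCCOc1cc(OC)c(Br)cc1C(C)=O` gives 35100000 nM

Among the compounds with values here, in a functional assay, with a stated time of 30 min (on this read-out higher numbers stand for weaker inhibition and lower numbers for stronger inhibition), compound 2 stands level with compound 1 within the scatter, and these are the only two compounds measured. Compound 3 `CCCCCCCCCCCCCCCCOc1cc(OC)c(Br)cc1C(C)=O` differs from compound 2 by hexyl in place of hydrogen on a saturated chain carbon, ten or more bonds along the chain from an oxygen on an aromatic ring and so carries a longer chain on the same core. Within the data shown here, the one measured step that bears on this is a 1.2-fold lower number from compound 1 to compound 2 (0.08 log units; within the scatter) and it also lengthens the chain. No step beyond the scatter is therefore expected in this assay in either direction, though a single step is thin evidence. The estimated change is a 1.2-fold lower number from compound 2 to compound 3 (0.07 log units; within the scatter) on that basis. Compound 3 is estimated at 30000000 nM with an expected range from 12000000 nM to 70000000 nM as its upper end.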

Compound 3, half-maximal inhibitory concentration: 6500000 nM
Compound 3: middle estimate off by 4.6-fold (0.66 log units), on the high side; measured number below the stated range.
By their numbers in this assay, from the lowest: compound 3; then compounds 2 and 1 (each within the scatter of the next).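

In this assay the chain is no longer flat: hexyl in place of hydrogen on a saturated chain carbon gives (a 5.4-fold lower number from compound 2 to compound 3 (0.73 log units; beyond the scatter)), whereas the earlier butyl step (a 1.2-fold lower number from compound 1 to compound 2 (0.08 log units; within the scatter)) stayed within the scatter. So this position responds to added chain carbons, but the response appears only in this second extension. Nothing measured here accounts for the step.

Going by these compounds, whether a still longer chain would lower the number further remains open. So does whether an amine or a carboxylic acid at the chain end would be tolerated.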